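This account rests on a few compounds, and the source may have more. Where it says the series, first, only, none or still open, it means among the compounds named here.

In a functional assay on NCI-H460 cells (Homo sapiens) for positive allosteric modulation, read by MTT assay, with stated times of 2 h and 72 h, tested at 1 uM (on this read-out lower numbers stand for stronger inhibition and higher numbers for weaker inhibition), compound 1 (`COc1ccc(C(=O)Nc2ccccc2-c2nnn(-c3ccc(OC)cc3)n2)cc1`) gives 305 nM and compound 2 (`COc1cccc(-n2nnc(-c3ccccc3NC(=O)c3ccc(N)cc3)n2)c1`) gives 217 nM. Compound 3 (`COc1cccc(-n2nnc(-c3ccccc3NC(=O)c3ccc(NC(C)=O)cc3)n2)c1`) gives 725 nM, the highest number of the three and beyond the scatter from both others, which makes it the weakest inhibitor so far. Compound 4 (`COc1cccc(-n2nnc(-c3ccccc3NC(=O)c3ccc(NC(=O)CBr)cc3)n2)c1`) differs from compound 3 in one place: bromo in place of hydrogen on a saturated chain carbon bound to a carbonyl carbon. This is bromo in place of hydrogen on a saturated chain carbon bound to a carbonyl carbon, so that acetamido becomes ((bromomethyl)carbonyl)amino. For the measured compounds named here, only one measured step touches this part of the structure, the modest 3.3-fold higher number from compound 2 to compound 3 (0.52 log units; beyond the scatter), where acetyl took the place of hydrogen on a nitrogen on an aromatic ring. Going by the values given here, no measured step introduces bromo, so the direction remains uncertain. A step of similar modest size is expected, leaning towards the lower numbers seen for the other two compounds. The expected step is a 2.4-fold lower number from compound 3 to compound 4 (0.38 log units; beyond the scatter). The estimate for compound 4 is 300 nM, with an expected range of 80 nM to 1000 nM.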

Compound 4, half-maximal inhibitory concentration: 241 nM
Beside the measured number, compound 4's estimate is 1.2-fold (0.10 log units) above it; the measured number falls inside the stated range.
By their numbers in this assay, from the lowest: compounds 2, 4 and 1 (each within the scatter of the next); then compound 3.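

In this assay, bromo in place of hydrogen on the saturated chain carbon bound to a carbonyl carbon gives a 3.0-fold lower number from compound 3 to compound 4 (0.48 log units; beyond the scatter) and so shows that this one atom on the acetamido chain changes the number beyond the scatter. The earlier step, a 3.3-fold higher number from compound 2 to compound 3 (0.52 log units; beyond the scatter), had suggested a cost for acylating the nitrogen, but (bromomethyl)carbonyl in place of hydrogen on that nitrogen gives a 1.1-fold higher number from compound 2 to compound 4 (0.05 log units; within the scatter) and is within the scatter, so the cost seen with acetyl does not extend to every acyl group here. Nothing measured here accounts for this difference.

Going by these compounds, whether a chlorine, a hydroxyl or a longer chain on this carbon would give a number close to that of compound 4 or to that of compound 3 stays open. On these data alone, it is also open whether bromo would produce a similar step on the core of compound 1.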